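From methylsulfanyl to trifluoromethoxy in compound 4

This account rests on a few compounds, and the source may have more. Where it says the series, first, only, none or still open, it means among the compounds named here.

Of the compounds shown here, three sharing one core have been read in a physicochemical assay for solubility, read by nephelometry, at pH 7.4; on this read-out lower numbers stand for lower solubility and higher numbers for higher solubility. Compound 1 `COc1cccc(NC(=O)c2nnn(Cc3ccc([S+](C)[O-])cc3)c2N)c1` gives > 250000 nM, which is a limit and not a number. Compound 2 `COc1cccc(NC(=O)c2nnn(Cc3ccc(C(C)C)cc3)c2N)c1` gives 14000 nM. Compound 3 `COc1cccc(NC(=O)c2nnn(Cc3ccc(SC)cc3)c2N)c1` gives < 12000 nM, which is also a limit. Compound 3 therefore stands with compound 2 at the low end of the numbers, far from compound 1. The large steps are an at least 17-fold lower number from compound 1 to compound 2 (1.25 log units; beyond the scatter) and an at least 20-fold lower number from compound 1 to compound 3 (1.31 log units; beyond the scatter), while an at least 1.1-fold lower number from compound 2 to compound 3 (0.06 log units; that floor lies within the scatter) has a floor that lies within the scatter.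

Compound 4 `COc1cccc(NC(=O)c2nnn(Cc3ccc(OC(F)(F)F)cc3)c2N)c1` differs by trifluoromethoxy in place of methylsulfanyl on an aromatic carbon, with trifluoromethoxy in place of methylsulfanyl on an aromatic carbon. Among the measured compounds shown here, no measured step tests this exchange directly. The closest guide is compound 3, since its step of an at least 1.1-fold lower number from compound 2 to compound 3 (0.06 log units; that floor lies within the scatter) also exchanges one group for another without the group of compound 1. The expected result is a step that the limit leaves unreadable from compound 3 to compound 4, with no change beyond the scatter in this assay. For compound 4 the estimated value is 9000 nM, with an expected range of 3500 nM to 20000 nM.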

Compound 4, solubility: 12000 nM
Beside the measured number, compound 4's estimate is 1.3-fold (0.12 log units) below it; the measured number falls inside the stated range.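

In this assay, trifluoromethoxy on this aromatic carbon gives a measured number rather than a limit, and that number cannot be told apart from the one for isopropyl: a 1.2-fold lower number from compound 2 to compound 4 (0.07 log units; within the scatter). Like the groups in compounds 2 and 3, trifluoromethoxy, with its five heavy atoms, leaves the number far from that of compound 1: an at least 20-fold lower number from compound 1 to compound 4 (1.31 log units; beyond the scatter). The exchange of methylsulfanyl for trifluoromethoxy itself gives a number no lower from compound 3 to compound 4 (the limit leaves the size open), and its size cannot be read, because compound 3 carries only a limit: the limit of < 12000 nM in this assay, at which 1 of the 4 values shown sits.

The compounds shown leave open whether an amine or a carboxylic acid in this place would read closer to compound 1 or closer to compounds 2 and 4. How large the gap from compound 1 really is also stays open: the limit of > 250000 nM in this assay, at which 1 of the 4 values shown sits.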